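Cytotoxicity on liver cells: benzyloxy analogue of compound 3

This account rests on a few compounds, and the source may have more. Where it says the series, first, only, none or still open, it means among the compounds named here.

Measured compounds, with their readings in an ADME assay on HepG2 cells (Homo sapiens) for cytotoxicity, read by CellTiter-Glo and resazurin assay, with a stated time of 72 h; a lower number here means that less compound is needed, a higher number that more compound is needed for the effect:
- compound 1 `CCOC(=O)CCCCCOc1cccc(CN(C(=O)c2ccc(-c3cccc(N(C)C)c3)cc2)C(C)C)c1`; in this assay compound 1 gives > 26000 nM, which is a limit of the assay and not a number.
- compound 2 `CCOC(=O)CCCCCOc1cccc(CN(C(=O)c2ccc(-c3cccc(OCC(C)C)c3)cc2)C(C)C)c1`; compound 2 gives > 26000 nM, likewise a limit.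
- compound 3 `CCOC(=O)CCCCCOc1cccc(CN(C(=O)c2ccc(-c3cccc(OC(C)C)c3)cc2)C(C)C)c1`; compound 3 gives > 26000 nM, again a limit.

Compound 3 therefore stands at the same limit as the other two members of the series, as the limit of > 26000 nM in this assay, at which 3 of the 3 values shown sit, records. From the compounds shown here alone, none of the three measured steps can be read: a step that the two limits leave unreadable from compound 1 to compound 2, a step that the two limits leave unreadable from compound 1 to compound 3 and a step that the two limits leave unreadable from compound 2 to compound 3 all sit between two limits, so their size and direction are unknown. Among the compounds with values here, the series so far shows no compound with a cytotoxicity reading inside the measurable range.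

Compound 4 `CCOC(=O)CCCCCOc1cccc(CN(C(=O)c2ccc(-c3cccc(OCc4ccccc4)c3)cc2)C(C)C)c1` is the next member. Its difference from compound 3 is benzyl in place of isopropyl on an oxygen on an aromatic ring. Within the data shown here, the only step that touches the same oxygen on the aromatic ring, a step that the two limits leave unreadable from compound 2 to compound 3, is unreadable, so no measured step gives a direction for the change to benzyl. The expectation is that compound 4 stays at the limit in this assay, with a step that the limit leaves unreadable from compound 3 to compound 4 that is not expected to be resolved. The estimate for compound 4 is 30000 nM, with a range from 12000 nM to 80000 nM.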

Compound 4, half-maximal effective concentration: > 26000 nM
Compound 4: no number, only a limit (the forecaster's own chance of this, stated with the estimate: 80%); the middle value is on the limit's open side.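

The steps from compound 1, compound 2 and compound 3 to compound 4 cannot be read, since each lies between two limits and so has neither size nor direction: the limit of > 26000 nM in this assay, at which 4 of the 4 values shown sit.

The compounds shown leave open where any of the four actually stands, and whether any change at this place gives a reading inside the measurable range.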